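Anilino ring substitution in a bromophenyl lactam series

The compounds below may be only part of what the source reports. "The series", "measured", "known", "first", "only" and "open" are said of these compounds alone.

Measured compounds:
compound 1 `O=C(C1=C(Nc2ccccc2)C(=O)N(CCCn2ccnc2)C1c1ccc(Br)cc1)c1ccccc1` — 21200 nM
compound 2 `Cc1ccc(NC2=C(C(=O)c3ccccc3)C(c3ccc(Br)cc3)N(CCCn3ccnc3)C2=O)cc1` — 25800 nM
compound 3 `O=C(C1=C(Nc2ccc(Cl)cc2)C(=O)N(CCCn2ccnc2)C1c1ccc(Br)cc1)c1ccccc1` — 25000 nM

All three were tested in a functional assay on NCI-H1299 cells (Homo sapiens) for antiproliferative activity, read by MTT assay, with a stated time of 72 h; on this read-out lower numbers stand for stronger inhibition and higher numbers for weaker inhibition. Compound 1 holds the lowest of the three numbers, yet its separation from the others is small: the methyl substitution gives a 1.2-fold higher number from compound 1 to compound 2 (0.09 log units; within the scatter) and the chloro substitution gives a 1.2-fold higher number from compound 1 to compound 3 (0.07 log units; within the scatter), and between compound 2 and compound 3 the difference is a 1.0-fold lower number from compound 2 to compound 3 (0.01 log units; within the scatter). No change on the anilino ring seen so far moves the read-out beyond the scatter.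

Compound 4 `O=C(C1=C(Nc2ccccc2Br)C(=O)N(CCCn2ccnc2)C1c1ccc(Br)cc1)c1ccccc1` has not been measured. Relative to compound 1 it carries the difference (bromo in place of hydrogen on an aromatic carbon), placed on an aromatic carbon of a six-membered aromatic ring of carbon only, ortho to a large group.

The relevant precedents are the two single substitutions on the same anilino ring, a 1.2-fold higher number from compound 1 to compound 2 (0.09 log units; within the scatter) and a 1.2-fold higher number from compound 1 to compound 3 (0.07 log units; within the scatter), both within scatter. A halogen comparable to chloro is introduced, though at a different place on the ring, so the expectation for compound 4 in this assay is a step of about a 1.0-fold higher number from compound 1 to compound 4 (0.02 log units; within the scatter), that is none beyond the scatter. Compound 4 is therefore estimated at 22000 nM, with a range of 11000 nM to 45000 nM.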

Compound 4, half-maximal inhibitory concentration: 15600 nM
Estimate against measurement, compound 4: 1.4-fold (0.15 log units) above; low and high end bracket the measured number.
By their numbers in this assay, from the lowest: compounds 4, 1, 3 and 2 (each within the scatter of the next).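

In this assay, bromo on an aromatic carbon of the anilino ring, ortho to a large group, gives (a 1.4-fold lower number from compound 1 to compound 4 (0.13 log units; within the scatter)), so this position, which compound 2 and compound 3 did not probe, also shows no step beyond the scatter. The 2-bromophenyl group set against the two other substituted anilino groups gives (a 1.6-fold lower number from compound 3 to compound 4 (0.20 log units; within the scatter)) and (a 1.7-fold lower number from compound 2 to compound 4 (0.22 log units; within the scatter)); these are larger steps than any among compound 1, compound 2 and compound 3, yet they too stay within the scatter, so the four compounds cannot be ranked and the anilino ring remains flat across methyl, chloro and bromo at the places tried. No measurement shown speaks to why the read-out stays flat at this ring.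

The compounds shown leave open whether an amine or a carboxylic acid on the anilino ring would move the read-out beyond the scatter. They also leave open how the read-out responds to changes elsewhere, such as a longer chain on the lactam nitrogen or a replacement of the bromophenyl group.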